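Swapping cyano for dimethylamino on compound 2

The source may report more compounds than this note shows. Statements on the series, on what has been measured and on what is new or still open speak of the compounds shown alone.

compound 1 `N#Cc1ccc(C(O)(c2ccc(Cl)cc2)c2cccnc2)cc1` gives > 100000 nM as a limit of the assay, not a number
compound 2 `N#Cc1ccc(C(O)(c2ccc(C(F)(F)F)cc2)c2cccnc2)cc1` gives 76500 nM

Going by the values given here, in an ADME assay on L6 cells (Rattus norvegicus) for cytotoxicity, read by resazurin assay, with a stated time of 72 h (on this read-out lower numbers stand for stronger inhibition and higher numbers for weaker inhibition), compound 2 gives 76500 nM as the only true number so far. Among the compounds with values here, the one measured step, an at least 1.3-fold lower number from compound 1 to compound 2 (0.11 log units; that floor lies within the scatter), put trifluoromethyl in place of chloro, so it does not touch the group changing now. Compound 3 `CN(C)c1ccc(C(O)(c2ccc(C(F)(F)F)cc2)c2cccnc2)cc1` carries dimethylamino in place of cyano on an aromatic carbon and keeps everything else from compound 2. Within the data shown here, with no measured step at this cyano group, no move beyond the scatter is expected in this assay in either direction. The estimate means a 1.3-fold lower number from compound 2 to compound 3 (0.11 log units; within the scatter) as the expected move. Compound 3 is estimated at 60000 nM with an expected range from 20000 nM to 100000 nM on repeated measurement.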

Compound 3, half-maximal inhibitory concentration: 59100 nM
For compound 3 the middle estimate is 1.0-fold (0.01 log units) above the measured one; low and high end bracket the measured number.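

At this place on the ring, para to a large group, dimethylamino in place of cyano gives a 1.3-fold lower number from compound 2 to compound 3 (0.11 log units; within the scatter) in this assay and so no real change. A nitrile and a dimethylamino group, which differ in heavy atoms and in the triple bond, cannot be told apart here. Values at this end of the scale lie close to a limit: the limit of > 100000 nM in this assay, at which 1 of the 3 values shown sits.

On these data alone, whether a carboxylic acid or a primary amine at this position would move the number beyond the scatter stays open. So does whether the same swap reads alike with chloro on the other ring.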